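Hydroxy to methylsulfonyl: working notes on the series

The compounds below may be only part of what the source reports. "The series", "measured", "known", "first", "only" and "open" are said of these compounds alone.

Measured in an ADME assay on microsomes from liver (Rattus norvegicus) for metabolic stability, read by LC-MS, with a stated time of 30 min, tested at 0.5 uM; a higher number here means that more of the compound is left, a lower number that less of the compound is left:
- compound 1 `c1ccc(-c2nc(-c3csc(N=C4NCCCN4)n3)cs2)cc1`: 31%
- compound 2 `Oc1cccc(-c2nc(-c3csc(N=C4NCCCN4)n3)cs2)c1`: 35%

With 35%, compound 2 lies within the scatter of compound 1, so the data set neither apart from the other. Compound 3 `CS(=O)(=O)c1cccc(-c2nc(-c3csc(N=C4NCCCN4)n3)cs2)c1` is not yet measured. It differs from compound 2 by methylsulfonyl in place of hydroxy on an aromatic carbon, meta to a large group (methylsulfonyl in place of hydroxy on an aromatic carbon). Going by the values given here, the only measured step that bears on this change is a number 4 percentage points higher from compound 1 to compound 2 (within the scatter), for hydroxy in place of hydrogen on an aromatic carbon. Among the compounds with values here, no measured compound carries methylsulfonyl, so that small step gives only weak guidance, and no step beyond the scatter is expected in either direction. The expected change is a number 1 percentage points higher from compound 2 to compound 3 (within the scatter). In this assay the estimate for compound 3 is 36%, with an expected range from 18% to 58%.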

Compound 3, percent of the compound remaining: 47%
The estimate for compound 3 lay 11 percentage points below the measured number; the measured number falls inside the stated range.
By their numbers in this assay, from the lowest: compounds 1 and 2 (each within the scatter of the next); then compound 3.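

In this assay, going by these compounds alone, methylsulfonyl on this aromatic carbon, meta to a large group, gives the first step at this position that lies beyond the scatter: a number 12 percentage points higher from compound 2 to compound 3 (beyond the scatter), and a number 16 percentage points higher from compound 1 to compound 3 (beyond the scatter). Hydroxy in place of hydrogen did not separate compound 1 and compound 2, whereas compound 3 stands apart from both, so the number at this position does respond to the group placed there, though only modestly. Nothing at hand accounts for this change.

As far as these compounds go, it remains open whether the higher number is particular to methylsulfonyl or would also appear with a nitrile, a carboxylic acid or an amine on this carbon. The compounds shown also leave open how methylsulfonyl would fare at another place on the same ring.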